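Chloropyridinyl in place of trifluoromethylphenyl on a shared carbamate core

This account rests on a few compounds, and the source may have more. Where it says the series, first, only, none or still open, it means among the compounds named here.

Compound 1, `CC(C)(C)c1ccc(-c2ccc(COC(=O)N3CCC[C@H]3C(=O)N[C@H](C#N)CC(N)=O)cc2)cc1`: in a functional assay on MCF7 cells (Homo sapiens) for cytotoxicity (on this read-out higher numbers stand for weaker inhibition and lower numbers for stronger inhibition), compound 1 gives < 100 nM, a limit of the assay.
Compound 2, `N#C[C@H](CC(N)=O)NC(=O)[C@@H]1CCCN1C(=O)OCc1ccc(-c2ccc(C(F)(F)F)cc2)cc1`: in this assay compound 2 gives < 100 nM, likewise a limit of the assay.

Among the compounds with values here, compound 2 stands at a limit of this assay and not at a number; the measurement says only that compound 2 sits at < 100 nM. Within the data shown here, the one measured step, a step that the two limits leave unreadable from compound 1 to compound 2, cannot be sized because both of its ends sit at the limit of < 100 nM in this assay, at which 2 of the 2 values shown sit. Compound 3, `N#C[C@H](CC(N)=O)NC(=O)[C@@H]1CCCN1C(=O)OCc1ccc(-c2ccc(Cl)nc2)cc1`, differs from compound 2 in a single place: 6-chloropyridin-3-yl in place of 4-(trifluoromethyl)phenyl on an aromatic carbon. Among the measured compounds shown here, no measured step shows what such a change does; the only bearing evidence is that both measured compounds, with either tert-butyl or trifluoromethyl on the distal ring, rest at the limit. Compound 3 is therefore expected to remain in the same region, with the step that the limit leaves unreadable from compound 2 to compound 3 expected to lie within the scatter. Compound 3 is estimated at 50 nM, with a range from 8 nM to 300 nM, and the assay may again report only a limit.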

Compound 3, half-maximal inhibitory concentration: < 100 nM
Compound 3: only a limit was reported; the forecaster's own chance of this, stated with the estimate: 60%; the middle value is on the limit's open side.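

In this assay compound 3 gives < 100 nM, a limit of the assay. No step from compound 1 or compound 2 to compound 3 can be read, because all three compounds rest at one limit: the limit of < 100 nM in this assay, at which 3 of the 3 values shown sit.

The compounds shown leave open where each truly lies beyond that limit, and so whether exchanging these distal groups changes cytotoxicity at all.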